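A Chloro Addition to an Amide Scaffold Already at the Limit

A few compounds are considered here, and "the series" means these few. Any claim that something is new, unique, unknown or untested is made for them only; others in the source may bear on it.

Compound 1, `CS(=O)(=O)c1ccc(C(=O)Nc2ccc(Cl)c(-c3nnc4c(Cl)cccn34)c2)c(Cl)c1`, gives in a functional assay on MDA-MB-468 cells (Homo sapiens) for antiproliferative activity, read by MTT assay, with a stated time of 72 h (a lower number here means a stronger inhibitor, a higher number a weaker inhibitor), only a limit of the assay, > 100000 nM.
Compound 2, `O=C(Nc1ccc(Cl)c(-c2nnc3c(Cl)cccn23)c1)c1ccccc1`, gives in this assay likewise only a limit of the assay, > 100000 nM.

For compound 2 no number is known, only a limit of the assay. Within the data shown here, the one further value shown, that of compound 1, is also a limit, so there is no step between measured compounds to learn from, only the observation that both values sit at the limit of > 100000 nM in this assay, at which 2 of the 2 values shown sit.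

Compound 3, `O=C(Nc1ccc(Cl)c(-c2nnc3c(Cl)cccn23)c1)c1ccccc1Cl`, is not yet measured. It differs from compound 2 by chloro in place of hydrogen on an aromatic carbon, ortho to a large group, so that the benzoyl becomes a (2-chlorophenyl)carbonyl.

Since both known values are limits, no direction for this change can be read from them, and the step of a number no higher from compound 2 to compound 3 (the limit leaves the size open) is expected to be none beyond the scatter, most likely with compound 3 itself reaching only a limit. In this assay compound 3 is therefore expected to give about 100000 nM, within a range from 30000 nM to 300000 nM.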

Compound 3, half-maximal inhibitory concentration: > 100000 nM
Compound 3: no number, only a limit; the forecaster's own chance of this, stated with the estimate: 75%; the middle value sits exactly at the limit.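

In this assay compound 3 gives only a limit of the assay, > 100000 nM. No step from compound 2 or compound 1 to compound 3 can be read: the limit of > 100000 nM in this assay, at which 3 of the 3 values shown sit.

The compounds shown leave open what number any of the three would give, and whether chloro in place of hydrogen changes the activity at all.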